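The source may hold more compounds than are shown below. What is called first, only, known or untested is meant among the compounds shown, and "the series" means these compounds.

Among the measured compounds shown here, compound 2 `Cc1ccc2cc(-c3ccc(Cl)nn3)c(=O)oc2c1` gives 2510 nM in an assay on cells for inhibition of Amine oxidase [flavin-containing] B (Homo sapiens), read by fluorescence and Amplex Red, with a stated time of 15 min (on this read-out lower numbers stand for stronger inhibition and higher numbers for weaker inhibition), the lowest of the three numbers so far; its nearest neighbour is compound 1 at a higher number beyond the scatter, and compound 3 stands further off. Compound 1 `Cc1ccc2oc(=O)c(-c3ccc(Cl)nn3)cc2c1` gives 13500 nM in this assay. Compound 1 and compound 2 are built from the same atoms joined differently; the difference between the two cores is not broken down here. Compound 3 `COc1ccc(-c2cc3cc(C)ccc3oc2=O)nn1` gives 17600 nM in this assay. Compound 3 arises from compound 1 by methoxy in place of chloro on an aromatic carbon, and the measured step is a 1.3-fold higher number from compound 1 to compound 3 (0.12 log units; within the scatter).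

Compound 4 `COc1ccc(-c2cc3ccc(C)cc3oc2=O)nn1` is not yet measured. It arises from compound 2 by the same kind of change, (methoxy in place of chloro on an aromatic carbon), with the place described in the same words as before. The change occurs twice in this set. In this assay the expected step is a 1.3-fold higher number from compound 2 to compound 4 (0.11 log units; within the scatter). That expectation rests on compound 1 and compound 3, where a 1.3-fold higher number from compound 1 to compound 3 (0.12 log units; within the scatter), a step within the scatter. Compound 4 is therefore expected to give 3200 nM in this assay, with a likely range from 1600 nM to 6500 nM.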

Compound 4, half-maximal inhibitory concentration: 13500 nM
For compound 4 the middle estimate is 4.2-fold (0.63 log units) below the measured one, outside the stated range (above it).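

Methoxy in place of chloro does not carry over with the same size between the two cores in this assay: the same change on two cores in this assay, a 1.3-fold higher number (0.12 log units; within the scatter) from compound 1 to compound 3 and a 5.4-fold higher number (0.73 log units; beyond the scatter) from compound 2 to compound 4, 4.1-fold (0.62 log units) apart, beyond the scatter of two such steps. On the core of compound 2 the change gives a 5.4-fold higher number from compound 2 to compound 4 (0.73 log units; beyond the scatter), whereas on the core of compound 1 it gives a 1.3-fold higher number from compound 1 to compound 3 (0.12 log units; within the scatter), so a step read on one of these cores was a poor guide to the other. The two pairs show that the step depends on the core here, but they do not show why, and they give no rule for any further core.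

The compounds shown leave open whether an amine, a hydroxyl group or a longer chain such as ethoxy at the same place would follow the chloro to methoxy step on either core. They also leave open how a carboxylic acid in place of the methyl group would behave on these cores.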